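The compounds below may be only part of what the source reports. "The series", "measured", "known", "first", "only" and "open" are said of these compounds alone.

In a functional assay on the whole organism for inhibition, with Mus musculus as the target, in the writhing test, with a stated time of 15 min, at a dose of 10 mg/kg (on this read-out higher numbers stand for more inhibition at the one dose given (going by the name of the read-out) and lower numbers for less inhibition), compound 3 `O=C1N=C(C2C(=O)c3ccccc3C2=O)CC(c2ccc(Cl)cc2)N1` gives 44%, the highest of the three numbers, although compound 1 `O=C1N=C(C2C(=O)c3ccccc3C2=O)CC(c2cccc([N+](=O)[O-])c2)N1`, which gives 36%, lies within the scatter of it. Compound 2 `O=C1N=C(C2C(=O)c3ccccc3C2=O)CC(/C=C/c2ccccc2)N1` gives 16%. Compound 4 `CN(C)c1ccc(C2CC(C3C(=O)c4ccccc4C3=O)=NC(=O)N2)cc1` differs from compound 3 in one place: dimethylamino in place of chloro on an aromatic carbon. Among the compounds with values here, no measured step exchanges one group for another on this aromatic ring, so the bearing steps are indirect. They are a number 8 percentage points higher from compound 1 to compound 3 (within the scatter) and a number 28 percentage points higher from compound 2 to compound 3 (beyond the scatter), both changing the group on a saturated ring carbon, with only the second beyond the scatter. A small change at the aromatic ring is therefore expected to move the number little, and the expected step is a number 6 percentage points lower from compound 3 to compound 4 (within the scatter). Compound 4 is estimated at 38%, with a range from 20% to 56%.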

Compound 4, a percentage reported as inhibition, in the whole organism at one dose (the size of the read-out at that dose, not a potency): 52%
Compound 4: the middle estimate sits 14 percentage points below what was measured; the measured number falls inside the stated range.
By their numbers in this assay, from the lowest: compound 2; then compounds 1, 3 and 4 (each within the scatter of the next, the first and the last beyond it).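

Among the compounds shown, this is the only step on the aromatic ring itself: in this assay, dimethylamino in place of chloro gives a number 8 percentage points higher from compound 3 to compound 4 (within the scatter), so the larger group brings no loss beyond the scatter. Compound 4 also separates from both other analogues, with a number 36 percentage points higher from compound 2 to compound 4 (beyond the scatter) and a number 16 percentage points higher from compound 1 to compound 4 (beyond the scatter), whereas compound 3 lies within the scatter of compound 1. Nothing measured here explains these steps. From the compounds shown here alone, it remains open how a primary amine or a methoxy group at this same place would read.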